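A few compounds are considered here, and "the series" means these few. Any claim that something is new, unique, unknown or untested is made for them only; others in the source may bear on it.

Measured so far:
- compound 1 `CNc1cc(Oc2ccc(NC(=O)Nc3cccc(C)c3)cc2)ncn1`: 1260 nM
- compound 2 `CNc1cc(Oc2c(F)cc(NC(=O)Nc3cccc(C(F)(F)F)c3)cc2F)ncn1`: 20 nM

In an assay on isolated protein for inhibition of serine/threonine-protein kinase TNNI3K (Homo sapiens) (a lower number here means a stronger inhibitor, a higher number a weaker inhibitor), compound 1 gives 1260 nM, the highest of the two numbers at hand. Among the measured compounds shown here, compound 2, which differs from it in several places at once, gives 20 nM in this assay, a far lower number and well beyond the scatter; with no single-point step between them, this pair only shows that a much stronger inhibitor exists.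

Compound 3 `CNc1cc(Oc2ccc(NC(=O)Nc3cccc(C(F)F)c3)cc2)ncn1` is the single-point neighbour of compound 1: difluoromethyl in place of methyl on an aromatic carbon, read one bond further out as 3-methylphenyl to 3-(difluoromethyl)phenyl. For the measured compounds named here, no measured step of this kind exists here, so the expectation rests on the values of compound 1 and compound 2 alone. A modest move toward a lower number, somewhat beyond the scatter, is expected for the step of a 3.2-fold lower number from compound 1 to compound 3 (0.50 log units; beyond the scatter). Compound 3 is therefore estimated to give about 400 nM in this assay, with a likely range from 150 nM to 1100 nM.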

Compound 3, half-maximal inhibitory concentration: 100 nM
Estimate against measurement, compound 3: 4.0-fold (0.60 log units) above; measured number below the stated range.
By their numbers in this assay, from the lowest: compound 2; then compound 3; then compound 1.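

In this assay, among the compounds shown here, the exchange of methyl for difluoromethyl on an aromatic carbon, meta to a large group, gives a 13-fold lower number from compound 1 to compound 3 (1.10 log units; beyond the scatter) and stands as the first change that can be read at a single place. Compound 1 and compound 2 differ in several places at once, so they could not tie any change in the number to one group, whereas this step shows that this aromatic carbon alone can carry a large difference while the rest of compound 1 stays untouched. No measurement at hand bears on what lies behind this step.

Still open, as far as these compounds go, is how a methoxy group, a chlorine atom or a nitrile would read on the same aromatic carbon, and whether monofluoromethyl there would already give part of this step. Also open is how the number of compound 2, 20 nM in this assay, divides between its trifluoromethyl group and its other fluorine atoms, a question that no single-place step shown here can answer.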